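This account rests on a few compounds, and the source may have more. Where it says the series, first, only, none or still open, it means among the compounds named here.

Compound 2, `CC(C)c1n[nH]c2c(NCc3ccc(-c4ccccn4)cc3)nc(SCCCO)nc12`, is the weakest inhibitor of growth among the three measured compounds in a functional assay on HT cells (Homo sapiens) for antiproliferative activity, read by fluorescence, with a stated time of 72 h (a higher number here means a weaker inhibitor of growth, a lower number a stronger inhibitor of growth), where compound 2 gives 109 nM. Its neighbours differ only on the chain attached to the sulfur: compound 1, `CC(C)c1n[nH]c2c(NCc3ccc(-c4ccccn4)cc3)nc(SCCO)nc12`, gives 48 nM, and compound 3, `CNCCSc1nc(NCc2ccc(-c3ccccn3)cc2)c2[nH]nc(C(C)C)c2n1`, gives 56 nM. The step of a 2.3-fold higher number from compound 1 to compound 2 (0.36 log units; beyond the scatter) is the only one that clears the scatter; the step of a 1.9-fold lower number from compound 2 to compound 3 (0.29 log units; within the scatter) and the step of a 1.2-fold higher number from compound 1 to compound 3 (0.07 log units; within the scatter) do not.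

Compound 4, `COCSc1nc(NCc2ccc(-c3ccccn3)cc2)c2[nH]nc(C(C)C)c2n1`, is not yet measured. It differs from compound 2 by methoxy in place of 2-hydroxyethyl on a saturated chain carbon bound to a sulfur, that is, (3-hydroxypropyl)sulfanyl becomes (methoxymethyl)sulfanyl. The measured steps show that changes on this chain move the number by modest amounts at most, and the shortest chain, in compound 1, gave the lowest number. Compound 4 is therefore expected to sit somewhat below compound 2, with an expected step of a 1.8-fold lower number from compound 2 to compound 4 (0.26 log units; within the scatter). The estimate for compound 4 in this assay is 60 nM, within a range from 25 nM to 150 nM.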

Compound 4, concentration for 50% growth inhibition: 340 nM
Estimate against measurement, compound 4: 5.7-fold (0.75 log units) below; measured number outside the range, above it.
By their numbers in this assay, from the lowest: compounds 1, 3 and 2 (each within the scatter of the next, the first and the last beyond it); then compound 4.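

In this assay, among the compounds shown here, the chain on the sulfur proves less forgiving than the earlier compounds suggested, since (methoxymethyl)sulfanyl gives a 3.1-fold higher number from compound 2 to compound 4 (0.49 log units; beyond the scatter), as well as a 6.1-fold higher number from compound 3 to compound 4 (0.78 log units; beyond the scatter) and a 7.1-fold higher number from compound 1 to compound 4 (0.85 log units; beyond the scatter). Each of these steps is larger than any step among compounds 1, 2 and 3, so compound 4 is the weakest inhibitor of growth of the four. The change from compound 2 alters two things at once: the hydrogen-bond donors in the changed group go from 1 to 0, and the chain is also rearranged and shortened, with its oxygen now inside the chain rather than at its end.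

No measurement shown here accounts for this rise. As far as these compounds go, a 2-methoxyethyl or 3-methoxypropyl chain on the sulfur would help separate the capped oxygen from the chain length, and these chains remain open here.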